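A few compounds are considered here, and "the series" means these few. Any claim that something is new, unique, unknown or untested is made for them only; others in the source may bear on it.

Measured in a functional assay on MDA-MB-231 cells (Homo sapiens) for inhibition, read by sulforhodamine B assay, with a stated time of 72 h (a higher number here means a weaker inhibitor of growth, a lower number a stronger inhibitor of growth), so far:
compound 1, `CNC(=O)CCc1ccncc1-c1ccc2ccccc2c1`: 8980 nM
compound 2, `O=C(O)CCc1ccncc1-c1ccc2ccccc2c1`: a limit, > 10000 nM
compound 3, `CNC(=O)/C=C/c1ccncc1-c1ccc2ccccc2c1`: 8680 nM

Compound 3 holds the lower of the two numbers recorded in this assay, with compound 1 its nearest neighbour: a 1.0-fold lower number from compound 1 to compound 3 (0.01 log units; within the scatter). For compound 2 only a limit is recorded, (the limit of > 10000 nM in this assay, at which 1 of the 3 values shown sits), so no number stands behind it.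

Compound 4, `O=C(/C=C/c1ccncc1-c1ccc2ccccc2c1)NC1CC1`, differs from compound 3 at the amide end: cyclopropyl in place of methyl on an amide-type nitrogen. The measured steps that touch this end of the molecule are the two that replace the methylamino group with hydroxy and back, an at least 1.1-fold higher number from compound 1 to compound 2 (0.04 log units; that floor lies within the scatter) and an at least 1.1-fold lower number from compound 2 to compound 3 (0.06 log units; that floor lies within the scatter). Both rest on the limit of compound 2 and neither is beyond the scatter. Among the measured compounds shown here, no measured step exchanges one carbon group for another on the amide-type nitrogen, so the change in compound 4 is untested here. On this evidence a step in this assay no larger than the scatter is expected, in either direction: a 1.1-fold lower number from compound 3 to compound 4 (0.04 log units; within the scatter). For compound 4 the expected value is 8000 nM, with a range from 3000 nM to 20000 nM, and a fair chance that only a limit is returned.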

Compound 4, concentration for 50% growth inhibition: 8420 nM
Estimate against measurement, compound 4: 1.1-fold (0.02 log units) below; low and high end bracket the measured number.
By their numbers in this assay, from the lowest: compounds 4, 3 and 1 (each within the scatter of the next). At a limit, above all of these: compound 2.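

On the amide-type nitrogen, cyclopropyl in place of methyl gives a 1.0-fold lower number from compound 3 to compound 4 (0.01 log units; within the scatter) in this assay. The wider exchange of 2-(methylcarbamoyl)ethyl for 2-(cyclopropylcarbamoyl)ethenyl gives a 1.1-fold lower number from compound 1 to compound 4 (0.03 log units; within the scatter) and also stays within the scatter. The exchange of 2-carboxyethyl for 2-(cyclopropylcarbamoyl)ethenyl gives an at least 1.1-fold lower number from compound 2 to compound 4 (0.07 log units; that floor lies within the scatter), and this step rests on a limit. For compound 2 only a limit is recorded: the limit of > 10000 nM in this assay, at which 1 of the 4 values shown sits.

No step shown lies beyond the scatter, so nothing here yet identifies a change that moves the number at this position. From the compounds shown here alone, whether a longer alkyl chain, an aminoethyl group or a phenyl ring on the amide-type nitrogen would do so remains open.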